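The compounds below may be only part of what the source reports. "The series", "measured", "known", "first", "only" and "open" are said of these compounds alone.

Measured compounds in an assay on HeLa cells for inhibition of sphingosine-1-phosphate transporter SPNS2 (Mus musculus), read by LC-MS, tested at 2 uM; on this read-out higher numbers stand for more inhibition at the one concentration tested (going by the name of the read-out) and lower numbers for less inhibition:
compound 1 `CCCCCCCCCCc1ccc(-c2noc(CCCCN)n2)cc1` gives 55%
compound 2 `CCCCCCCCCCc1ccc(-c2noc([C@@H]3CC[C@H](N)C3)n2)cc1` gives 38%
compound 3 `CCCCCCCCCCc1ccc(-c2noc([C@H](N)CCCCN)n2)cc1` gives 50%

Compound 2 stands lowest of the three numbers in this assay: a number 17 percentage points lower from compound 1 to compound 2 (beyond the scatter) and a number 12 percentage points higher from compound 2 to compound 3 (beyond the scatter), both beyond the scatter. Compound 4 `CCCCCCCCCCc1ccc(-c2noc(CC(O)CN3CCCC3)n2)cc1` is still unmeasured; relative to compound 2 the change is 2-hydroxy-3-(pyrrolidin-1-yl)propyl in place of 3-aminocyclopentyl on an aromatic carbon. The two steps that bear on it are those that leave compound 2, each exchanging the 3-aminocyclopentyl for an open chain bearing a nitrogen, and each raised the number by a modest amount. For the measured compounds named here, compound 4 likewise replaces the ring with an open chain bearing a nitrogen, though no measured pair covers the hydroxyl or the pyrrolidine, so the parallel is loose. A modest rise in this assay is therefore expected, a number 8 percentage points higher from compound 2 to compound 4 (within the scatter). For compound 4 the estimate is 46%, expected within 26% to 66%.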

Compound 4, a percentage reported as inhibition, at one concentration (the size of the read-out at that concentration, not a potency): 21%
Estimate against measurement, compound 4: 25 percentage points above; measured number outside the range, below it.
By their numbers in this assay, from the lowest: compound 4; then compound 2; then compounds 3 and 1 (each within the scatter of the next).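

In this assay, an open chain bearing a nitrogen does not by itself raise the number at this position: 2-hydroxy-3-(pyrrolidin-1-yl)propyl in place of 3-aminocyclopentyl gives a number 17 percentage points lower from compound 2 to compound 4 (beyond the scatter), the opposite direction to the earlier open chains. The same group also gives a number 29 percentage points lower from compound 3 to compound 4 (beyond the scatter) and a number 34 percentage points lower from compound 1 to compound 4 (beyond the scatter), so open chains bearing a nitrogen differ widely here. Nothing available explains this fall.

As far as these compounds go, the hydroxyl and the pyrrolidine enter together in compound 4, so their separate shares stay open. A 3-(pyrrolidin-1-yl)propyl chain without the hydroxyl, or a 3-amino-2-hydroxypropyl chain with a primary amine, would separate them.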